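Same Added Methyl on Two Cores, One Expected Step

The compounds below may be only part of what the source reports. "The series", "measured", "known", "first", "only" and "open" are said of these compounds alone.

Compound 1 `CO[C@@]12CCN(C)C[C@H]1[C@H](c1ccc3ccccc3c1)C(C#N)=C(N)O2` and compound 2 `CCN1CC[C@@]2(OC)OC(N)=C(C#N)[C@@H](c3ccc4ccccc4c3)[C@@H]2C1` share a core, and compound 2 carries methyl in place of hydrogen on a saturated chain carbon bound to an amine nitrogen in a ring. In a functional assay on trachea (Cavia porcellus) (on this read-out lower numbers stand for stronger inhibition and higher numbers for weaker inhibition), compound 1 gives 24200 nM, while compound 2 gives 28300 nM, which is a 1.2-fold higher number from compound 1 to compound 2 (0.07 log units; within the scatter). Compound 3 `CO[C@@]12CCN(C)C[C@H]1[C@H](c1ccc(Cl)cc1Cl)C(C#N)=C(N)O2` has a different core; the difference between the two cores is not broken down here. In this assay compound 3 gives 14900 nM. Compound 4 `CCN1CC[C@@]2(OC)OC(N)=C(C#N)[C@@H](c3ccc(Cl)cc3Cl)[C@@H]2C1` differs from compound 3 by methyl in place of hydrogen on a saturated chain carbon bound to an amine nitrogen in a ring, the same change made at the same place as between compound 1 and compound 2. For compound 4 a step of similar size is expected, a 1.2-fold higher number from compound 3 to compound 4 (0.07 log units; within the scatter), resting on the fact that a 1.2-fold higher number from compound 1 to compound 2 (0.07 log units; within the scatter) stayed within the scatter. Compound 4 is therefore estimated at 17500 nM, most likely between 8000 nM and 38000 nM.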

Compound 4, half-maximal inhibitory concentration: 27100 nM
The estimate for compound 4 lay 1.5-fold (0.19 log units) below the measured number; measured number inside the range.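

In this assay, methyl in place of hydrogen gives a 1.8-fold higher number from compound 3 to compound 4 (0.26 log units; within the scatter), so this step also stays inside the scatter. Set beside the step on the other core, it does not differ by more than repeated measurements would allow: the same change on two cores in this assay, a 1.2-fold higher number (0.07 log units; within the scatter) from compound 1 to compound 2 and a 1.8-fold higher number (0.26 log units; within the scatter) from compound 3 to compound 4, 1.6-fold (0.19 log units) apart, within the scatter of two such steps. On these two cores, then, the change carries over without a detectable difference, but two pairs with every step inside the scatter do not show that the methyl has any effect of its own, or that the same would hold on other cores.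

The compounds shown leave open what a longer chain, such as propyl in place of the ethyl, would do. Going by these compounds, whether a step of any clear size can be reached at this place also remains open.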